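The source may report more compounds than this note shows. Statements on the series, on what has been measured and on what is new or still open speak of the compounds shown alone.

Compound 1: `CC(C)(C)OC(=O)N1C[C@@H](n2cc(-c3ccc4c(N)n[nH]c4c3)nn2)C[C@H]1C(=O)Nc1ccc(Br)cc1` — 23%
Compound 2: `CC(C)(C)OC(=O)N1C[C@@H](n2cc(-c3ccc4nc(N)sc4n3)nn2)C[C@H]1C(=O)Nc1ccc(Cl)c(C(F)(F)F)c1` — 27.4%
Compound 3: `CC(C)(C)OC(=O)N1C[C@@H](n2cc(-c3ccc4nc(N)sc4n3)nn2)C[C@H]1C(=O)Nc1ccc(Cl)cc1Cl` — 28.3%

In a functional assay on K562/Adr cells (Homo sapiens) for inhibition, read by MTT assay, with a stated time of 48 h, tested at 30 uM (a lower number here means less inhibition, a higher number more inhibition at the concentration tested (going by the name of the read-out)), compound 3 gives 28.3%. Its number is not separated beyond the scatter from compound 2, as the step of a number 0.9 percentage points higher from compound 2 to compound 3 (within the scatter) shows, nor from compound 1, whose value sits a little lower but still within the scatter. All three compounds therefore show much the same degree of inhibition at this concentration.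

Compound 4, `CC(C)(C)OC(=O)N1C[C@@H](n2cc(-c3ccc4nc(N)sc4n3)nn2)C[C@H]1C(=O)Nc1ccc(Br)cc1`, shares its core with compound 2 and compound 3 and differs from compound 3 in one place: 4-bromophenyl in place of 2,4-dichlorophenyl on an amide-type nitrogen. Within the data shown here, the only measured step that bears on this change is the swap of the aryl group on the amide nitrogen from compound 2 to compound 3, which stayed within the scatter. The same 4-bromophenyl as in compound 4 sits on a different core in compound 1, and compound 1 gives 23%, again close to the others. Nothing in these numbers points to a shift beyond the scatter.

Compound 4 is therefore expected to give 25% in this assay, estimated to fall between 15% and 35%. That estimate means a step of a number 3.3 percentage points lower from compound 3 to compound 4 (within the scatter), expected to lie within the scatter.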

Compound 4, a percentage reported as inhibition, at one concentration (the size of the read-out at that concentration, not a potency): 31.7%
Compound 4: the middle estimate sits 6.7 percentage points below what was measured, and the stated range covers the measured number.
By their numbers in this assay, from the lowest: compounds 1, 2, 3 and 4 (each within the scatter of the next).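

In this assay, the aryl group on the amide-type nitrogen of this core accepts 4-bromophenyl in place of either earlier group without a shift beyond the scatter, as a number 3.4 percentage points higher from compound 3 to compound 4 (within the scatter) and a number 4.3 percentage points higher from compound 2 to compound 4 (within the scatter) show. Among these compounds, with 4-bromophenyl held constant, the same compound also gives the first direct comparison of the two cores, and a number 8.7 percentage points higher from compound 1 to compound 4 (within the scatter) shows that this exchange does not separate them beyond the scatter either. No supporting data bear on why these numbers lie so close together.

All the aryl groups shown on the amide-type nitrogen are halogen-bearing phenyl rings, so it remains open how a phenyl ring carrying an amine or a carboxylic acid, or a simple alkyl chain, would behave there. Also open, on these data alone, is what a free amine in place of the tert-butoxycarbonyl group would give.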